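Changing the ring on the benzylic carbon of compound 1

The compounds below may be only part of what the source reports. "The series", "measured", "known", "first", "only" and "open" are said of these compounds alone.

Measured compounds:
compound 1 `O=C(O)c1ccccc1-c1ccc(CCc2ncc(Cc3cccc(Cl)c3)[nH]2)cc1`: 825 nM
compound 2 `CCCCc1cnc(C(CC)Cc2ccc(-c3ccccc3C(=O)O)cc2)[nH]1`: 2720 nM
compound 3 `O=C(O)c1ccccc1-c1ccc(CCc2ncc(-c3ccccc3)[nH]2)cc1`: 4950 nM

In an in vitro functional assay on cells for agonist activity at Bombesin receptor subtype-3 (Homo sapiens), read by luminescence and calcium flux (on this read-out higher numbers stand for an effect only at larger amounts of compound and lower numbers for an effect already at smaller amounts), compound 1 gives the lowest of the three numbers. Compound 2 gives a higher number that lies beyond the scatter, and compound 3 gives a higher number still. Within the data shown here, the one step that differs in a single place is a 6.0-fold higher number from compound 1 to compound 3 (0.78 log units; beyond the scatter). There a phenyl stands in place of the 3-chlorobenzyl group, and the number is higher.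

Compound 4 `COc1ccccc1Cc1cnc(CCc2ccc(-c3ccccc3C(=O)O)cc2)[nH]1` is not yet measured. It differs from compound 1 in one place: 2-methoxyphenyl in place of 3-chlorophenyl on a saturated chain carbon bound to an aromatic carbon. Among the measured compounds shown here, no measured pair compares two different rings on that saturated chain carbon, so the step from compound 1 to compound 3 bears on this change only loosely; it shows that the site tolerates alteration, with a modest loss. Compound 4 is therefore expected to stay near compound 1, with a step of a 1.7-fold higher number from compound 1 to compound 4 (0.23 log units; within the scatter) that may not exceed the scatter. The estimate for compound 4 is 1400 nM, within 450 nM to 4500 nM.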

Compound 4, half-maximal effective concentration: 1720 nM
For compound 4 the middle estimate is 1.2-fold (0.09 log units) below the measured one; low and high end bracket the measured number.
By their numbers in this assay, from the lowest: compound 1; then compounds 4, 2 and 3 (each within the scatter of the next, the first and the last beyond it).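

In this assay, among these compounds, the exchange of 3-chlorophenyl for 2-methoxyphenyl on the saturated chain carbon gives the first direct comparison of two rings at this site, and it amounts to a 2.1-fold higher number from compound 1 to compound 4 (0.32 log units; beyond the scatter), a modest change. The exchange of phenyl for 2-methoxybenzyl on the aromatic carbon gives a 2.9-fold lower number from compound 3 to compound 4 (0.46 log units; beyond the scatter), so both benzyl groups shown, 3-chlorobenzyl and 2-methoxybenzyl, give lower numbers than phenyl at that place. No supporting measurement is available to explain either step.

The step from 3-chlorobenzyl to 2-methoxybenzyl changes both the group on the ring and where it sits, so the compounds shown cannot separate these two changes. Going by these compounds, an unsubstituted benzyl, a 2-chlorobenzyl and a 3-methoxybenzyl remain open, and each would help to separate them.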